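Series notes: alpha-keto oxazoles, step to the iodo analogue

The compounds below may be only part of what the source reports. "The series", "measured", "known", "first", "only" and "open" are said of these compounds alone.

Measured so far:
compound 1, `O=C(CCCCCCc1ccccc1)c1ncc(-c2cccc(O)c2)o1`, 50 nM
compound 2, `COc1ccnc(-c2cnc(C(=O)CCCCCCc3ccccc3)o2)c1`, 0.8 nM

In an assay (Rattus norvegicus) for inhibition of Fatty-acid amide hydrolase 1 (Homo sapiens) (a higher number here means a weaker inhibitor, a lower number a stronger inhibitor), compound 2 gives the lowest number of the two; its nearest neighbour is compound 1, and the step of a 63-fold lower number from compound 1 to compound 2 (1.80 log units; beyond the scatter) is large and beyond the scatter.

Compound 3, `O=C(CCCCCCc1ccccc1)c1ncc(I)o1`, has not been measured. It differs from compound 2 by iodo in place of 4-methoxypyridin-2-yl on an aromatic carbon.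

Going by the values given here, only one measured step exists, and it concerns a different exchange: in compound 1 and compound 2 one aromatic group on the shared core replaces another, whereas here the whole 4-methoxypyridin-2-yl group leaves and a single iodo enters. That step shows the group at this place matters a great deal, so a large move in the opposite direction is expected. Compound 3 is expected to give 200 nM in this assay, with a range of 30 nM to 1500 nM, a step of a 250-fold higher number from compound 2 to compound 3 (2.40 log units; beyond the scatter), expected but not anchored by a directly comparable measurement.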

Compound 3, inhibition constant: 3 nM
For compound 3 the middle estimate is 67-fold (1.82 log units) above the measured one, and the stated range ends above it.
By their numbers in this assay, from the lowest: compound 2; then compound 3; then compound 1.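

In this assay, the exchange of the 4-methoxypyridin-2-yl group for a single iodo gives a 3.8-fold higher number from compound 2 to compound 3 (0.57 log units; beyond the scatter) and counts as only a modest loss, although the earlier large step suggested that this place was highly sensitive. Iodo in place of 3-hydroxyphenyl gives a 17-fold lower number from compound 1 to compound 3 (1.22 log units; beyond the scatter) and counts as a large gain, so among these three compounds a six-membered aromatic ring at this place is not needed for a low number, and the ring of compound 1 does worse than a single atom. Nothing on hand explains this order.

Still open, on these data alone, is whether chloro, bromo, nitrile or plain hydrogen at this place would stay near compound 3. As far as these compounds go, how a pyridin-2-yl group without the methoxy would compare with the 4-methoxypyridin-2-yl group of compound 2 is also open.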